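Methyl in place of chloro on the shared core

This account rests on a few compounds, and the source may have more. Where it says the series, first, only, none or still open, it means among the compounds named here.

Compound 2 `CN1CCC(C(=O)c2cccc(NC(=O)c3ccc(F)cc3)c2Cl)CC1` gives 1700 nM; compound 1 `CN1CCC(C(=O)c2cccc(NC(=O)c3ccc(F)cc3)c2O)CC1` gives 1100 nM.

In an assay on isolated protein for binding affinity to 5-hydroxytryptamine receptor 1F (Homo sapiens), read by radioligand binding (on this read-out higher numbers stand for weaker inhibition and lower numbers for stronger inhibition), compound 2 gives the highest of the two numbers, and the nearest is compound 1, whose value lies within the scatter of it. Going by the values given here, the one measured step, a 1.5-fold higher number from compound 1 to compound 2 (0.19 log units; within the scatter), is the only step that bears on the change to compound 3 `Cc1c(NC(=O)c2ccc(F)cc2)cccc1C(=O)C1CCN(C)CC1`, and it does not go beyond the scatter. Compound 3 differs from compound 2 by methyl in place of chloro on an aromatic carbon. Both groups entering at this aromatic carbon so far, hydroxy and chloro, have left the number in this assay within the scatter of each other, so no step beyond the scatter is expected for compound 3 in either direction. For compound 3 the step of a 1.1-fold lower number from compound 2 to compound 3 (0.05 log units; within the scatter) is therefore expected to stay small. Compound 3 is estimated at 1500 nM, with a range from 600 nM to 4000 nM.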

Compound 3, inhibition constant: 870 nM
Beside the measured number, compound 3's estimate is 1.7-fold (0.24 log units) above it; low and high end bracket the measured number.
By their numbers in this assay, from the lowest: compounds 3, 1 and 2 (each within the scatter of the next).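

In this assay, methyl becomes the third group at this aromatic carbon, and neither a 2.0-fold lower number from compound 2 to compound 3 (0.29 log units; within the scatter) nor a 1.3-fold lower number from compound 1 to compound 3 (0.10 log units; within the scatter) leaves the scatter. Hydroxy, chloro and methyl therefore cannot be told apart by their numbers here, although the exchange of chloro for methyl gives the largest of the three steps at this position. Nothing at hand accounts for these numbers or for the size of any step.

The compounds shown leave open whether an amine, a carboxylic acid or a longer chain at this aromatic carbon would give a step beyond the scatter. They also leave open whether these three groups would stay within the scatter of one another if another part of the shared core were changed.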